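This account rests on a few compounds, and the source may have more. Where it says the series, first, only, none or still open, it means among the compounds named here.

Measured compounds:
Compound 1, `O=C(O)/C=N/OC(c1ccc(OCc2ccc3ccccc3n2)cc1)C1CCCCCC1`; in a functional assay for inhibition of Polyunsaturated fatty acid 5-lipoxygenase (Homo sapiens) (a lower number here means a stronger inhibitor, a higher number a weaker inhibitor), compound 1 gives 18 nM.
Compound 2, `C/C(=N\OC(c1ccc(OCc2ccc3ccccc3n2)cc1)C1CCCCCC1)C(=O)O`; in this assay compound 2 gives 13 nM.

Compound 2 has the lower of the two numbers, but its nearest neighbour is compound 1, and the step of a 1.4-fold lower number from compound 1 to compound 2 (0.14 log units; within the scatter) lies within the scatter, so the two compounds cannot be told apart on these data.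

Compound 3, `C/C(=N\OC(CCCc1ccc(F)cc1)c1ccc(OCc2ccc3ccccc3n2)cc1)C(=O)O`, has not yet been measured in this assay. It differs from compound 2 in one place: 3-(4-fluorophenyl)propyl in place of cycloheptyl on a saturated chain carbon bound to an aromatic carbon and an oxygen. Going by the values given here, the only measured step, from compound 1 to compound 2, concerns the substituent on the oxime oxygen, not the carbon that carries the cycloheptyl group, so it does not bear on this change; it shows only that a small alteration elsewhere left the number within the scatter. Among the compounds with values here, no measured pair here speaks to the exchange of a ring for a 3-(4-fluorophenyl)propyl chain, so the direction of the step is open and the range must be wide. Compound 3 is expected to give 20 nM in this assay, with a range from 5 nM to 80 nM, which would be a step of a 1.5-fold higher number from compound 2 to compound 3 (0.19 log units; within the scatter).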

Compound 3, half-maximal inhibitory concentration: 9 nM
Compound 3: middle estimate off by 2.2-fold (0.35 log units), on the high side; the range from low to high includes it.
By their numbers in this assay, from the lowest: compounds 3, 2 and 1 (each within the scatter of the next).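

At the saturated chain carbon bound to an aromatic carbon and an oxygen, exchanging cycloheptyl for 3-(4-fluorophenyl)propyl gives, in this assay, a 1.4-fold lower number from compound 2 to compound 3 (0.16 log units; within the scatter), so compound 2 and compound 3 cannot be told apart on these data. Going by these compounds alone, this is the first pair to speak to this position, and it shows that 3-(4-fluorophenyl)propyl, which carries a six-membered aromatic ring, can take the place of cycloheptyl, a seven-membered non-aromatic ring, with no change in the number that can be read beyond the scatter. Nothing measured here offers an explanation for this result, so the step stands as an observation only.

The compounds shown leave open what a small group such as methyl, a shorter chain such as ethyl, or a chain ending in an amine would give at this carbon, and so how far this position accepts other groups. They also leave open what the fluorine of the 3-(4-fluorophenyl)propyl group contributes, since every compound that carries this chain also carries that fluorine.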